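Aminothiophene amides: pyrrolidine in place of cyclohexylamine

The source may report more compounds than this note shows. Statements on the series, on what has been measured and on what is new or still open speak of the compounds shown alone.

Measured so far:
compound 1, `Nc1sc(-c2ccc(Br)cc2)c(-c2ccc(Cl)cc2)c1C(=O)NC1CCCCC1`, 28400 nM
compound 2, `Nc1sc(-c2ccc(Br)cc2)c(-c2ccc(Cl)cc2)c1C(=O)N1CCCC1`, 37500 nM
compound 3, `Nc1sc(-c2ccc([N+](=O)[O-])cc2)c(-c2ccc(Cl)cc2)c1C(=O)NC1CCCCC1`, 25900 nM

All three were read in a functional assay on PC-3 cells (Homo sapiens) for cytotoxicity, read by sulforhodamine B assay, with a stated time of 72 h; a higher number here means a weaker inhibitor, a lower number a stronger inhibitor. The change pyrrolidin-1-yl in place of cyclohexylamino on a carbonyl carbon gave a 1.3-fold higher number from compound 1 to compound 2 (0.12 log units; within the scatter). The cores of compound 1 and compound 3 differ by nitro in place of bromo on an aromatic carbon, with a 1.1-fold lower number from compound 1 to compound 3 (0.04 log units; within the scatter); the three values sit close together.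

Compound 4, `Nc1sc(-c2ccc([N+](=O)[O-])cc2)c(-c2ccc(Cl)cc2)c1C(=O)N1CCCC1`, has not yet been measured. It repeats the same change on compound 3: pyrrolidin-1-yl in place of cyclohexylamino on a carbonyl carbon. The place is the same in both cases, so the same change is made twice among the compounds shown. Going by the values given here, with only one earlier instance, the expectation for compound 4 rests on that single step, a 1.3-fold higher number from compound 1 to compound 2 (0.12 log units; within the scatter), and on compound 3 at 25900 nM. The estimated step for compound 4 is a 1.3-fold higher number from compound 3 to compound 4 (0.12 log units; within the scatter). The estimate for compound 4 in this assay is 34000 nM, expected between 17000 nM and 70000 nM.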

Compound 4, half-maximal inhibitory concentration: 42600 nM
The estimate for compound 4 lay 1.3-fold (0.10 log units) below the measured number, and the stated range covers the measured number.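

In this assay, pyrrolidin-1-yl in place of cyclohexylamino on a carbonyl carbon gives a 1.6-fold higher number from compound 3 to compound 4 (0.22 log units; within the scatter), and the two instances of this change do not differ measurably: the same change on two cores in this assay, a 1.3-fold higher number (0.12 log units; within the scatter) from compound 1 to compound 2 and a 1.6-fold higher number (0.22 log units; within the scatter) from compound 3 to compound 4, 1.2-fold (0.10 log units) apart, within the scatter of two such steps. Nitro in place of bromo on an aromatic carbon gives a 1.1-fold higher number from compound 2 to compound 4 (0.06 log units; within the scatter), and its two instances also agree: the same change on two cores in this assay, a 1.1-fold lower number (0.04 log units; within the scatter) from compound 1 to compound 3 and a 1.1-fold higher number (0.06 log units; within the scatter) from compound 2 to compound 4, 1.2-fold (0.10 log units) apart, within the scatter of two such steps. Going by these compounds alone, all of these steps lie within the scatter, so this agreement shows only that neither change moved the number measurably on these cores, not that a real effect transfers from one core to another.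

Going by these compounds, it remains open whether a morpholine or a longer alkyl chain on the carbonyl carbon would give a step beyond the scatter. The same holds for an amine or a carboxylic acid in place of nitro on the aromatic carbon.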